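This account rests on a few compounds, and the source may have more. Where it says the series, first, only, none or still open, it means among the compounds named here.

Compound 1 `O[C@@H]1[C@H](O)CS[C@H]1Cn1cnc2c(NCc3cccc(Cl)c3)ncnc21` is the reference point of the series. In an assay on CHO cells for displacement of a labelled ligand from adenosine receptor A3 (Homo sapiens), with a stated time of 60 min, tested at 10 uM (a lower number here means less inhibition, a higher number more inhibition at the concentration tested (going by the name of the read-out)), compound 1 gives 8.9%. Compound 2 `O[C@@H]1[C@H](O)CS[C@H]1Cn1cnc2c(NCc3cccc(Cl)c3)nc(Cl)nc21` gives 13.6% and compound 3 `O[C@@H]1[C@H](O)CS[C@H]1Cn1cnc2c(NCc3cccc(I)c3)nc(Cl)nc21` gives 10%, and the three numbers all lie within the scatter of one another, so no ordering among them is claimed. Compound 4 `O[C@@H]1[C@H](O)CS[C@H]1Cn1cnc2c(NCc3cccc(I)c3)ncnc21` differs from compound 1 by iodo in place of chloro on an aromatic carbon. Within the data shown here, the one measured step of the same kind, a number 3.6 percentage points lower from compound 2 to compound 3 (within the scatter), stayed within the scatter, and the step of a number 4.7 percentage points higher from compound 1 to compound 2 (within the scatter) did likewise. On this basis no step beyond the scatter is expected in this assay for compound 4. Compound 4 is therefore estimated at 8%, with a range of 1% to 18%. The expected step is a number 0.9 percentage points lower from compound 1 to compound 4 (within the scatter).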

Compound 4, a percentage reported as inhibition, at one concentration (the size of the read-out at that concentration, not a potency): 13.9%
Estimate against measurement, compound 4: 5.9 percentage points below; the measured number falls inside the stated range.
By their numbers in this assay, from the lowest: compounds 1, 3, 2 and 4 (each within the scatter of the next).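

In this assay, among these compounds, the change from 3-chlorobenzyl to 3-iodobenzyl now has a second reading, a number 5 percentage points higher from compound 1 to compound 4 (within the scatter), and the two readings do not separate: the same change on two cores in this assay, a number 3.6 percentage points lower (within the scatter) from compound 2 to compound 3 and a number 5 percentage points higher (within the scatter) from compound 1 to compound 4, 8.6 percentage points apart, within the scatter of two such steps Hydrogen in place of chloro on the other aromatic carbon, now read with the iodo group present, gives a number 3.9 percentage points higher from compound 3 to compound 4 (within the scatter), and this change also reads alike on both cores: the same change on two cores in this assay, a number 4.7 percentage points higher (within the scatter) from compound 1 to compound 2 and a number 3.9 percentage points lower (within the scatter) from compound 4 to compound 3, 8.6 percentage points apart, within the scatter of two such steps No step among the four compounds lies beyond the scatter, whichever of the two places is changed.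

Open, as far as these compounds go, is whether an amine or a carboxylic acid in place of the iodo would give a step beyond the scatter in this assay.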